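A few compounds are considered here, and "the series" means these few. Any claim that something is new, unique, unknown or untested is made for them only; others in the source may bear on it.

Compound 3 `Cc1ccc2nc(/N=C3\C(=O)N(CN4CCCCC4)c4cccc(Br)c43)sc2c1` carries the highest of the three numbers in hand: in an ADME assay on 184B5 cells (Homo sapiens) for cytotoxicity, read by sulforhodamine B assay, with a stated time of 48 h (on this read-out lower numbers stand for stronger inhibition of growth and higher numbers for weaker inhibition of growth), compound 3 gives 85200 nM. Compound 2 `Cc1ccc2nc(/N=C3\C(=O)N(CN(C)C)c4cccc(Br)c43)sc2c1` gives 74800 nM, a value within the scatter of compound 3, while compound 1 `O=C1C(=O)N(CN(c2ccccc2)c2ccccc2)c2ccccc21` gives 33700 nM, a value that lies beyond the scatter of compound 3. Going by the values given here, the only single-point step among the measured compounds, a 1.1-fold higher number from compound 2 to compound 3 (0.06 log units; within the scatter), is within the scatter. Compound 4 `Cc1ccc2nc(/N=C3\C(=O)N(CN4CCCCC4)c4cccc(Cl)c43)sc2c1` differs from compound 3 by chloro in place of bromo on an aromatic carbon. Among the compounds with values here, no measured step bears on a swap of one halogen for another on the core; the one step available alters the group on the saturated chain carbon and, being within the scatter, offers no guidance on direction. With nothing in the series pointing either way, the expectation for a 1.0-fold lower number from compound 3 to compound 4 (0.00 log units; within the scatter) is no step beyond the scatter. Compound 4 is therefore estimated at 85000 nM, with a range from 42000 nM to 170000 nM.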

Compound 4, concentration for 50% growth inhibition: 82300 nM
Beside the measured number, compound 4's estimate is 1.0-fold (0.01 log units) above it, and the stated range covers the measured number.
By their numbers in this assay, from the lowest: compound 1; then compounds 2, 4 and 3 (each within the scatter of the next).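

In this assay, chloro in place of bromo on an aromatic carbon of the shared core gives a 1.0-fold lower number from compound 3 to compound 4 (0.02 log units; within the scatter), so the two halogens cannot be told apart at this position. Going by these compounds alone, this is the first reading of a change on the six-membered aromatic ring of carbon only, and it holds for the piperidin-1-yl side of the series, where compound 3 and compound 4 both carry that group. No measurement in hand speaks to why the two halogens read alike.

Open, from the compounds shown here alone, is whether this position tolerates anything other than a halogen, such as a hydrogen, a methoxy group, an amine or a carboxylic acid. Also open, going by these compounds, is whether the same halogen swap reads alike with dimethylamino on the saturated chain carbon, the group in compound 2.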